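Dichlorophenyl pattern on the aromatic nitrogen of the shared core

The source may hold more compounds than are shown below. What is called first, only, known or untested is meant among the compounds shown, and "the series" means these compounds.

Compound 1 `COc1cc(-c2ncnn2-c2ccccc2)cc(OC)c1OC` is the parent of the set. In a functional assay on Jurkat cells (Homo sapiens) for antiproliferative activity, read by MTT assay, with a stated time of 72 h (on this read-out lower numbers stand for stronger inhibition and higher numbers for weaker inhibition), compound 1 gives > 10000 nM, which is a limit of the assay and not a number. Compound 2 `COc1cc(-c2ncnn2-c2ccc(Cl)c(Cl)c2)cc(OC)c1OC` carries the 3,4-dichlorophenyl in place of phenyl on an aromatic nitrogen. In this assay compound 2 gives > 10000 nM, again a limit and not a number. The step that the two limits leave unreadable from compound 1 to compound 2 therefore cannot be read in size or direction; both values sit at the limit of > 10000 nM in this assay, at which 2 of the 2 values shown sit, and compound 2 stands at that limit with nothing resolved beneath it.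

Compound 3 `COc1cc(-c2ncnn2-c2ccc(Cl)cc2Cl)cc(OC)c1OC` differs from compound 2 by 2,4-dichlorophenyl in place of 3,4-dichlorophenyl on an aromatic nitrogen. Among the compounds with values here, no measured step in this assay shows how moving a chlorine between ring positions acts, and the only step in hand, from compound 1 to compound 2, is unreadable. The expectation for compound 3 rests on both measured compounds sitting at the limit, so no shift beyond the scatter is expected, and the step that the limit leaves unreadable from compound 2 to compound 3 is an estimate of no change. Compound 3 is estimated at 15000 nM in this assay, with a range from 4000 nM to 60000 nM, and most likely reported only as a limit.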

Compound 3, half-maximal inhibitory concentration: > 10000 nM
Compound 3 gave a limit, no number (the forecaster's own chance of this, stated with the estimate: 80%); the middle value lies beyond the limit too.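

Compound 3 adds no readable step: its steps from compound 1 and from compound 2 cannot be read, as compounds 1, 2 and 3 all give a limit and not a number: the limit of > 10000 nM in this assay, at which 3 of the 3 values shown sit.

The compounds shown leave open whether any phenyl, 3,4-dichlorophenyl or 2,4-dichlorophenyl change on the shared core alters activity in this assay at all.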